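This account rests on a few compounds, and the source may have more. Where it says the series, first, only, none or still open, it means among the compounds named here.

Working notes on the series. Among the compounds with values here, compound 1 `CCOC(=O)c1cnc(NCc2ccc(F)cc2)n2nc(-c3ccco3)nc12` is the anchor: in an assay on CHO cells for displacement of a labelled ligand from adenosine receptor A3 (Homo sapiens) (a lower number here means a stronger inhibitor, a higher number a weaker inhibitor), compound 1 gives 46.3 nM, the lowest of the three numbers so far. Compound 2 `CCOC(=O)c1cnc(N(C)C)n2nc(-c3ccco3)nc12` gives 275 nM in this assay, and compound 3 `CCOC(=O)c1cnc(NC2CCCCC2)n2nc(-c3ccco3)nc12` gives 131 nM. The measured steps all concern the substituent on the amino side of the core: a 5.9-fold higher number from compound 1 to compound 2 (0.77 log units; beyond the scatter), a 2.8-fold higher number from compound 1 to compound 3 (0.45 log units; beyond the scatter) and a 2.1-fold lower number from compound 2 to compound 3 (0.32 log units; beyond the scatter), each modest and each beyond the scatter.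

Compound 4 `O=C(O)c1cnc(NCc2ccc(F)cc2)n2nc(-c3ccco3)nc12` differs from compound 1 in a different place altogether: hydrogen in place of ethyl on an oxygen next to a carbonyl group, that is, ethoxycarbonyl to carboxy. Within the data shown here, none of the three measured steps touches this oxygen or the carbonyl group, so no step in hand bears on the change, and there is no measured precedent for replacing ethyl with hydrogen at this position. The expectation for this assay therefore rests on the structural change alone and carries a wide range. The step from compound 1 to compound 4 is expected to be an 8.6-fold higher number from compound 1 to compound 4 (0.94 log units; beyond the scatter), a weakening. Compound 4 is estimated at 400 nM in this assay, with a range from 60 nM to 4000 nM.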

Compound 4, inhibition constant: 14000 nM
Compound 4: middle estimate off by 35-fold (1.54 log units), on the low side, outside the stated range (above it).
By their numbers in this assay, from the lowest: compound 1; then compound 3; then compound 2; then compound 4.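

Hydrogen in place of ethyl on an oxygen next to a carbonyl group gives a 300-fold higher number from compound 1 to compound 4 (2.48 log units; beyond the scatter) in this assay, the only large step in the series so far. The largest step on the amino side, a 5.9-fold higher number from compound 1 to compound 2 (0.77 log units; beyond the scatter), is modest by comparison, so among the compounds shown this oxygen is the place where a single change moves the number furthest, and the carboxy compound 4 stands well apart from the three ethoxycarbonyl compounds. No measurement is at hand that would account for the size of this step.

Open, from the compounds shown here alone, is whether a methyl ester, a longer-chain ester or an amide at this carbonyl stays near compound 1 or falls toward compound 4. Also open, going by these compounds, is whether ethoxycarbonyl to carboxy costs as much with cyclohexylamino or dimethylamino on the core in place of (4-fluorobenzyl)amino.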